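The source may report more compounds than this note shows. Statements on the series, on what has been measured and on what is new or still open speak of the compounds shown alone.

Of the compounds shown here, three from one series have been tested in an ADME assay on MDCK cells (Canis lupus familiaris) for cytotoxicity; on this read-out lower numbers stand for higher toxicity in this test and higher numbers for lower toxicity in this test. Compound 1, with the structure `Cn1ccnc1Sc1cnc(-c2ccccc2)nc1-c1ccccc1O`, gives in this assay a reading of 120000 ug/mL. Compound 2, `CC(C)(C)c1ncc(Sc2nc[nH]n2)c(-c2ccccc2O)n1`, gives 160000 ug/mL, and compound 3, `Cn1ccnc1Sc1cnc(C(C)(C)C)nc1-c1cc(Cl)ccc1O`, gives 111000 ug/mL. On these three numbers compound 1 sits within the scatter of both of its companions: its gap to compound 3 is small, and its gap to compound 2 is also small, so no order among the three can be read from them. All three share a core, and in all three the cytotoxic concentration lies very high.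

Compound 4, `Cn1ccnc1Sc1cnc(N)nc1-c1ccccc1O`, has not yet been measured. It differs from compound 1 in one place: amino in place of phenyl on an aromatic carbon. For the measured compounds named here, no pair of measured compounds in this set differs by such an exchange, so the step has no direct precedent here. Since compound 1 with 120000 ug/mL and the two other compounds all sit at very high concentrations and differ from each other only within the scatter, the step from compound 1 to compound 4 is expected to be small, estimated as no change at the digits printed from compound 1 to compound 4 (within the scatter), with no clear direction. Compound 4 is therefore expected to give about 120000 ug/mL in this assay, within a range from 60000 ug/mL to 240000 ug/mL.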

Compound 4, half-maximal cytotoxic concentration: 388000 ug/mL
Beside the measured number, compound 4's estimate is 3.2-fold (0.51 log units) below it, and the stated range ends below it.
By their numbers in this assay, from the lowest: compounds 3, 1 and 2 (each within the scatter of the next); then compound 4.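

For the compounds shown here, the exchange of phenyl for amino on the aromatic carbon between two ring nitrogen atoms gives the first step in this set that can be read in this assay, with a 3.2-fold higher number from compound 1 to compound 4 (0.51 log units; beyond the scatter) and thus towards lower toxicity in this test. The three earlier compounds allowed no order to be read, whereas this comparison shows that the reading at this position, para to the (1-methyl-1H-imidazol-2-yl)sulfanyl group, can move beyond the scatter, even though the step is only modest. No measurement at hand tells whether the step goes with the loss of the phenyl ring or with the arrival of the amino group, and no other data bear on its cause.

The compounds shown leave open whether the step belongs to the amino group alone or would also appear at this position with a methyl, a methoxy or a dimethylamino group. They also leave open whether the same exchange gives a step of similar size when the 2-hydroxyphenyl group carries a chlorine, as it does in compound 3.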